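The compounds below may be only part of what the source reports. "The series", "measured", "known", "first", "only" and "open" are said of these compounds alone.

For the measured compounds named here, in a functional assay on ZR-75-1 cells (Homo sapiens) for inhibition, read by sulforhodamine B assay (on this read-out higher numbers stand for weaker inhibition of growth and lower numbers for stronger inhibition of growth), compound 1 (`Fc1ccc(-c2ccc(-c3ccc(-c4nc5ccccc5[nH]4)cc3)cc2)cc1`) gives 100000 nM and compound 2 (`FC(F)(F)c1ccc(-c2ccc(-c3ccc(-c4nc5ccccc5[nH]4)cc3)cc2)cc1`) gives 48300 nM, the lower of the two numbers so far. Compound 3 (`COc1ccc(-c2ccc(-c3ccc(-c4nc5ccccc5[nH]4)cc3)cc2)cc1`) keeps the shared core but has methoxy in place of trifluoromethyl on an aromatic carbon. Going by the values given here, only one measured step bears on this change, a 2.1-fold lower number from compound 1 to compound 2 (0.32 log units; beyond the scatter), which is modest but beyond the scatter and also alters the group on that aromatic carbon. A similarly modest move toward a higher number is therefore expected, a 1.3-fold higher number from compound 2 to compound 3 (0.13 log units; within the scatter). Compound 3 is estimated at 65000 nM, with an expected range of 25000 nM to 100000 nM.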

Compound 3, concentration for 50% growth inhibition: 35100 nM
The estimate for compound 3 lay 1.9-fold (0.27 log units) above the measured number, and the stated range covers the measured number.
By their numbers in this assay, from the lowest: compounds 3 and 2 (each within the scatter of the next); then compound 1.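

Trifluoromethyl and methoxy on this aromatic carbon cannot be told apart: the change gives a 1.4-fold lower number from compound 2 to compound 3 (0.14 log units; within the scatter) even though methoxy brings a hydrogen-bond acceptor that trifluoromethyl lacks. Fluoro is now the outlier against both groups, since methoxy in its place gives a 2.8-fold lower number from compound 1 to compound 3 (0.45 log units; beyond the scatter) and the step from fluoro to trifluoromethyl also lies beyond the scatter. Nothing available explains these differences. Still open, as far as these compounds go, is whether an amine or a carboxylic acid here would shift the number further. A longer chain such as ethoxy is equally untested among these compounds.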